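This account rests on a few compounds, and the source may have more. Where it says the series, first, only, none or still open, it means among the compounds named here.

Of the compounds shown here, three have been measured in a physicochemical assay for lipophilicity; a higher number here means a more lipophilic compound, a lower number a more polar compound. Compound 1 `COc1cc(/C=C2\CCC/C(=C\c3ccccc3[N+](=O)[O-])C2=O)cc(OC)c1OC` gives 4.86, compound 2 `O=C1/C(=C/c2ccccc2)CCC/C1=C\c1ccc([N+](=O)[O-])cc1` gives 5.08, and compound 3 `O=C1/C(=C/c2ccc(Cl)cc2)CCC/C1=C\c1ccccc1[N+](=O)[O-]` gives 4.86. The value of compound 2 lies within the usual scatter of those of both compound 1 and compound 3, so the three compounds cannot be told apart on this read-out. Compound 4 `CN(C)c1ccc(/C=C2\CCC/C(=C\c3ccc([N+](=O)[O-])cc3)C2=O)cc1` has not yet been measured in this assay. It differs from compound 2 in one place: dimethylamino in place of hydrogen on an aromatic carbon. Among the compounds with values here, no measured pair in the set shows this change, so there is no step to lean on. From compound 2 to compound 4 a small upward step, or none beyond the scatter, is expected, a number 0.17 log units higher from compound 2 to compound 4 (within the scatter). Compound 4 is therefore estimated at 5.25, with a range from 4.85 to 5.65.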

Compound 4, partition coefficient: 5.08
For compound 4 the middle estimate is 0.17 log units above the measured one; the range from low to high includes it.
By their numbers in this assay, from the lowest: compounds 1, 3, 2 and 4 (each within the scatter of the next).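

In this assay, within the data shown here, the first single-place step in this set gives a reading for dimethylamino in place of hydrogen on an aromatic carbon, para to a large group: no change at the digits printed from compound 2 to compound 4 (within the scatter). On this one pair, the read-out therefore does not separate phenyl from 4-(dimethylamino)phenyl. No measurement shown bears on the reason for this result.

On these data alone, whether a carboxylic acid or a longer alkyl chain at this place would also stay within the scatter remains open. So does whether dimethylamino behaves the same way on the other aromatic ring.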